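The source may hold more compounds than are shown below. What is called first, only, known or untested is meant among the compounds shown, and "the series" means these compounds.

Compound 1 `O=C(COc1ccc(C(=O)/C=C/c2cccc(Cl)c2)cc1)N[C@H]1CCOC1=O` is the reference point of this small set. In a functional assay on DU-145 cells (Homo sapiens) for antiproliferative activity, read by MTT assay, with a stated time of 72 h (on this read-out lower numbers stand for stronger inhibition and higher numbers for weaker inhibition), compound 1 gives 3700 nM, the lowest of the two numbers obtained. The nearest number belongs to compound 3 `CCOc1ccccc1OCCSC(=S)N[C@H]1CCOC1=O`, which in this assay gives 28300 nM, and the gap between these two lies beyond the scatter of the method. Compound 2 `Cc1cc(Cl)ccc1NCC(=O)N[C@H]1CCOC1=O` returns only a limit in this assay, > 64000 nM, and no number (the limit of > 64000 nM in this assay, at which 1 of the 3 values shown sits).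

Compound 4 `O=C(COc1ccc(C(=O)/C=C/c2ccccc2)cc1)N[C@H]1CCOC1=O` is the partner of compound 1 in the step followed here. The change is hydrogen in place of chloro on an aromatic carbon. For the measured compounds named here, no measured pair in this set shows the effect of this change, so the expectation rests on the size of the change alone: a single heavy atom leaves and nothing replaces it, so the step is taken as a small one, a modest weakening at most, close to the scatter. Compound 4 is therefore expected to give about 6000 nM in this assay, within 2500 nM to 15000 nM. The step this estimate means, a 1.6-fold higher number from compound 1 to compound 4 (0.21 log units; within the scatter), is expected to stay near the scatter.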

Compound 4, half-maximal inhibitory concentration: 48300 nM
Compound 4: the middle estimate sits 8.1-fold (0.91 log units) below what was measured, and the stated range ends below it.
By their numbers in this assay, from the lowest: compound 1; then compounds 3 and 4 (each within the scatter of the next). At a limit, above all of these: compound 2.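

Going from 3-chlorophenyl to phenyl is not a small edit here: the change gives a 13-fold higher number from compound 1 to compound 4 (1.12 log units; beyond the scatter) on this read-out.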